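Extending the acrylamide chain on a fluoroindole series

The compounds below may be only part of what the source reports. "The series", "measured", "known", "first", "only" and "open" are said of these compounds alone.

Of the compounds shown here, three sharing one core have been measured in a functional assay on HepG2 cells (Homo sapiens) for antiproliferative activity, read by MTT assay, with a stated time of 72 h; a lower number here means a stronger inhibitor, a higher number a weaker inhibitor. Compound 1 `C=C(Cl)C(=O)Nc1cc(Nc2ncc(C#N)c(-c3cn(C)c4ccccc34)n2)c(OC)cc1N(C)CCN(C)C` gives 115 nM, compound 2 `CCC/C=C\C(=O)Nc1cc(Nc2nc(C)cc(-c3cn(C)c4ccccc34)n2)c(OC)cc1N(C)CCN(C)C` gives 365 nM, and compound 3 `C=CC(=O)Nc1cc(Nc2nccc(-c3cn(C)c4ccc(F)cc34)n2)c(OC)cc1N(C)CCN(C)C` gives 429 nM. Compound 3 therefore carries the highest of the three numbers; its nearest neighbour is compound 2, whose number lies within the scatter of it, while compound 1 sits beyond the scatter with the lowest number of the set.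

Compound 4 `COc1cc(N(C)CCN(C)C)c(NC(=O)/C=C\C(C)C)cc1Nc1nccc(-c2cn(C)c3ccc(F)cc23)n1` is the next member. It differs from compound 3 in one place: 3-methylbut-1-en-1-yl in place of vinyl on a carbonyl carbon. Among the compounds with values here, no pair already measured isolates this change, so the size of the step is uncertain. Compound 2, which bears a longer unsaturated chain on the same carbonyl, gives a number within the scatter of compound 3, and nothing among the three points to a large move in either direction.

For compound 4 the expected value in this assay is 500 nM, with a range from 200 nM to 1300 nM. This estimate corresponds to an expected step of a 1.2-fold higher number from compound 3 to compound 4 (0.07 log units; within the scatter), not beyond the scatter.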

Compound 4, half-maximal inhibitory concentration: 3920 nM
The estimate for compound 4 lay 7.8-fold (0.89 log units) below the measured number; measured number above the stated range.
By their numbers in this assay, from the lowest: compound 1; then compounds 2 and 3 (each within the scatter of the next); then compound 4.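

In this assay, 3-methylbut-1-en-1-yl in place of vinyl on a carbonyl carbon gives a 9.1-fold higher number from compound 3 to compound 4 (0.96 log units; beyond the scatter), a step beyond the scatter. Within the data shown here, this pair is the first in the set to isolate a change at this position, and it shows that the number here is sensitive to the group on the carbonyl: with the rest of the structure held constant, 5 heavy atoms in place of 2 go with a clearly weaker inhibitor. Nothing available accounts for the size of this step.

The compounds shown leave open whether the change in the number follows the length of the chain or its branching, since a single step cannot separate the two. An unbranched pent-1-en-1-yl chain or a dimethylaminomethyl-substituted vinyl group on the same carbonyl, with the rest of compound 3 unchanged, would test this.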